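Carboxylic Acid in Place of Nitro on the Benzyl Ring

The source may report more compounds than this note shows. Statements on the series, on what has been measured and on what is new or still open speak of the compounds shown alone.

Three measured compounds share the core of compound 1 `COc1cc(OC)c(/C=C/S(=O)(=O)Cc2cc(OC)c(OC)c(OC)c2)c(OC)c1` and differ only in the group carried on the second ring. In a functional assay on DU-145 cells (Homo sapiens) for antiproliferative activity, read by trypan blue exclusion (on this read-out higher numbers stand for weaker inhibition and lower numbers for stronger inhibition), compound 1 reaches only a limit of the assay, > 20000 nM. Among the compounds with values here, compound 2 `COc1cc(OC)c(/C=C/S(=O)(=O)Cc2ccc(Cl)cc2)c(OC)c1` gives 7500 nM in this assay, and compound 3 `COc1cc(OC)c(/C=C/S(=O)(=O)Cc2ccc([N+](=O)[O-])cc2)c(OC)c1` gives 15000 nM; these two values lie within the scatter of each other, as the single measured step, a 2.0-fold higher number from compound 2 to compound 3 (0.30 log units; within the scatter), shows. Compound 4 `COc1cc(OC)c(/C=C/S(=O)(=O)Cc2ccc(C(=O)O)cc2)c(OC)c1` has not been measured. It differs from compound 3 by carboxy in place of nitro on an aromatic carbon. Within the data shown here, only that step from chloro to nitro bears on this change, and it stayed within the scatter, so it sets no clear direction. Compound 4 is expected to give 22000 nM, with a range from 7000 nM to 70000 nM, meaning an expected step of a 1.5-fold higher number from compound 3 to compound 4 (0.17 log units; within the scatter). The estimate allows that this assay reports only a limit.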

Compound 4, half-maximal inhibitory concentration: 10000 nM
Compound 4: middle estimate off by 2.2-fold (0.34 log units), on the high side; the measured number falls inside the stated range.
By their numbers in this assay, from the lowest: compounds 2, 4 and 3 (each within the scatter of the next). At a limit, above all of these: compound 1.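

Putting carboxy in place of nitro, on an aromatic carbon para to a large group, adds a hydrogen-bond donor, yet in this assay it gives a 1.5-fold lower number from compound 3 to compound 4 (0.18 log units; within the scatter) and carboxy in place of chloro gives a 1.3-fold higher number from compound 2 to compound 4 (0.12 log units; within the scatter) in the same read-out. Chloro, nitro and carboxy at this position therefore all read alike, and a donor on this group does not set compound 4 apart from compound 2 or compound 3. Nothing measured here accounts for this sameness.

As far as these compounds go, whether an amine, a methyl ester or a longer chain at this position would move the number beyond the scatter remains open.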